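The source may hold more compounds than are shown below. What is called first, only, known or untested is meant among the compounds shown, and "the series" means these compounds.

The measured compounds are compound 1 `CCCCCNC(=O)NS(=O)(=O)c1cc(C#N)ccc1Oc1ccccc1C` with 2240 nM, compound 2 `Cc1cccc(Oc2ccc(C#N)cc2S(=O)(=O)NC(=O)NC(C)C)c1` with 2380 nM and compound 3 `Cc1cccc(Oc2ccc(C#N)cc2S(=O)(=O)NC(=O)NC(C)(C)C)c1` with 1050 nM, all in a functional assay on HEK293 cells for antagonist activity at thromboxane A2 receptor (Homo sapiens), read by fluorescence and calcium flux; a lower number here means a stronger inhibitor, a higher number a weaker inhibitor.

Within the data shown here, compound 3 holds the lowest number of the three; compound 1 is nearest, and the only measured step, a 2.3-fold lower number from compound 2 to compound 3 (0.36 log units; beyond the scatter), is a change on the urea chain. Compound 4 `CCCCCNC(=O)NS(=O)(=O)c1cc(C#N)ccc1Oc1cccc(C)c1` differs from compound 3 by pentyl in place of tert-butyl on an amide-type nitrogen. Among the measured compounds shown here, no measured step bears on this exact change; compound 1 also carries a pentyl on that nitrogen, though on a different core, and in this assay compound 1 gives 2240 nM. Compound 4 is therefore expected to give a somewhat higher number, a 1.7-fold higher number from compound 3 to compound 4 (0.23 log units; within the scatter), an estimate of 1800 nM with a range from 700 nM to 4500 nM.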

Compound 4, half-maximal inhibitory concentration: 1330 nM
Estimate against measurement, compound 4: 1.4-fold (0.13 log units) above; low and high end bracket the measured number.
By their numbers in this assay, from the lowest: compounds 3, 4, 1 and 2 (each within the scatter of the next, the first and the last beyond it).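

In this assay pentyl in place of tert-butyl on an amide-type nitrogen gives a 1.3-fold higher number from compound 3 to compound 4 (0.10 log units; within the scatter) and pentyl in place of isopropyl gives a 1.8-fold lower number from compound 2 to compound 4 (0.25 log units; within the scatter), so neither step separates pentyl from the two branched groups at this position. The 3-methylphenyl in place of 2-methylphenyl on the oxygen gives a 1.7-fold lower number from compound 1 to compound 4 (0.23 log units; within the scatter), which also separates nothing. Nothing shown explains these numbers.

Still open, on these data alone, is whether a longer chain, a cyclohexyl group or a terminal amine on that nitrogen gives a number beyond the scatter from compound 4.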